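Solubility notes on a hydroxamic acid series

The source may report more compounds than this note shows. Statements on the series, on what has been measured and on what is new or still open speak of the compounds shown alone.

Measured compounds in a physicochemical assay for solubility, read by HPLC, in phosphate buffer, with a stated time of 24 h, at pH 7.4, tested at 100 uM; a higher number here means a more soluble compound, a lower number a less soluble compound:

compound 1, `O=C(CCCCCNc1c(Nc2ccccc2)c(=O)c1=O)NO`: 47000000 nM
compound 2, `CN(C)c1ccc(Nc2c(NCCCCCC(=O)NO)c(=O)c2=O)cc1`: 12000000 nM
compound 3, `CC(CCCCC(=O)NO)Nc1c(Nc2ccccc2)c(=O)c1=O`: 93000000 nM

Compound 1 is the parent. Compound 2 carries the change dimethylamino in place of hydrogen on an aromatic carbon and shows a 3.9-fold lower number from compound 1 to compound 2 (0.59 log units; beyond the scatter); compound 2 stands lowest of the three. Compound 3 carries the change methyl in place of hydrogen on a saturated chain carbon bound to a nitrogen on an aromatic ring and a saturated chain carbon and shows a 2.0-fold higher number from compound 1 to compound 3 (0.30 log units; within the scatter), so compound 1 and compound 3 are not separated in this assay.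

Compound 4, `C[C@H](CCCCC(=O)NO)Nc1c(Nc2ccc(N(C)C)cc2)c(=O)c1=O`, is not yet measured. It differs from compound 2 by methyl in place of hydrogen on a saturated chain carbon bound to a nitrogen on an aromatic ring and a saturated chain carbon, the same change as methyl in place of hydrogen on a saturated chain carbon bound to a nitrogen on an aromatic ring and a saturated chain carbon, at a place described in the same words. The cores of compound 2 and compound 4 differ from those of compound 1 and compound 3 by dimethylamino in place of hydrogen on an aromatic carbon.

Among the compounds with values here, the step from compound 2 to compound 4 in this assay is expected to be about a 1.7-fold higher number from compound 2 to compound 4 (0.22 log units; within the scatter), resting on the one earlier example, a 2.0-fold higher number from compound 1 to compound 3 (0.30 log units; within the scatter), which stayed within the scatter. Compound 4 is therefore expected to give about 20000000 nM in this assay, with the estimate spanning 8000000 nM to 50000000 nM.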

Compound 4, solubility: 80000000 nM
Beside the measured number, compound 4's estimate is 4.0-fold (0.60 log units) below it, outside the stated range (above it).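

In this assay methyl in place of hydrogen on a saturated chain carbon gives a 6.7-fold higher number from compound 2 to compound 4 (0.82 log units; beyond the scatter) on the core of compound 2, against a 2.0-fold higher number from compound 1 to compound 3 (0.30 log units; within the scatter) on the core of compound 1, so the change separates the pair on one core and not on the other. Within the data shown here, this shows that in these two pairs the size of the step did not carry from one core to the other; it does not show a rule for other cores, since each core offers only one pair. Nothing at hand accounts for the difference between the two pairs.

Open, as far as these compounds go, is whether a step of this size on the core of compound 2 belongs to methyl alone or would also appear with ethyl at the same place. Also open, from the compounds shown here alone, is how the change behaves when a carboxylic acid stands in place of the dimethylamino, and what the opposite stereoisomer of compound 4 would give.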